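Pyridyl Nitrogen Shifts on a Weakly Inhibiting Series

This account rests on a few compounds, and the source may have more. Where it says the series, first, only, none or still open, it means among the compounds named here.

Compound 2 `CS(=O)(=O)c1ccc2nc(-c3ccc(-c4ccncc4)cc3)[nH]c2c1` carries a pyridin-4-yl group on the shared core. In an assay on isolated protein for inhibition of stearoyl-CoA desaturase 5 (Homo sapiens) (on this read-out higher numbers stand for weaker inhibition and lower numbers for stronger inhibition), compound 2 gives only a limit of > 20000 nM, not a number. Among the measured compounds shown here, its single structural neighbour among the measured compounds is compound 1 `CS(=O)(=O)c1ccc2nc(-c3ccc(-c4ccccc4)cc3)[nH]c2c1`, which bears a phenyl group at the same place. In this assay compound 1 likewise gives only a limit, > 10000 nM. The step that the two limits leave unreadable from compound 1 to compound 2 therefore has no readable size; the two values are the limits the limit of > 10000 nM in this assay, at which 1 of the 2 values shown sits, and (the limit of > 20000 nM in this assay, at which 1 of the 2 values shown sits), so neither the direction nor the magnitude of exchanging phenyl for pyridin-4-yl can be taken from them.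

Compound 3 `CS(=O)(=O)c1ccc2nc(-c3ccc(-c4ccccn4)cc3)[nH]c2c1` differs from compound 2 by pyridin-2-yl in place of pyridin-4-yl on an aromatic carbon. For the measured compounds named here, the only measured step that touches this position is the unreadable one just described, so no direction can be drawn from the data. With both measured compounds sitting at limits of this assay, compound 3 is expected to stay in the same weak region, with a step of a number no higher from compound 2 to compound 3 (the limit leaves the size open) estimated to fall within the scatter and a fair chance of another limit. The estimate for compound 3 is 20000 nM, expected between 4000 nM and 100000 nM.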

Compound 3, half-maximal inhibitory concentration: > 20000 nM
Compound 3: a limit, no number; the forecaster's own chance of this, stated with the estimate: 75%; the middle value sits exactly at the limit.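

Compound 3 gives only a limit in this assay, > 20000 nM, so none of the steps among compound 1, compound 2 and compound 3 can be read: the limit of > 20000 nM in this assay, at which 2 of the 3 values shown sit.

The compounds shown leave open whether phenyl, pyridin-4-yl and pyridin-2-yl differ at all in this assay, in either direction or size.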